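This account rests on a few compounds, and the source may have more. Where it says the series, first, only, none or still open, it means among the compounds named here.

Series notes. Four compounds share one core; the variation followed here sits on the ring that carries the carbonyl. Compound 1 `COc1cc(-c2nnc3n2NC(c2cccs2)C(C(=O)c2ccc(C)cc2)S3)cc(OC)c1OC` in a functional assay on HepG2 cells (Homo sapiens) for cytotoxicity, read by MTT assay, with a stated time of 48 h (on this read-out higher numbers stand for weaker inhibition and lower numbers for stronger inhibition), gives 3700 nM. Compound 2 `COc1ccc(C(=O)C2Sc3nnc(-c4cc(OC)c(OC)c(OC)c4)n3NC2c2cccs2)cc1` gives in this assay 68000 nM, the change being an 18-fold higher number from compound 1 to compound 2 (1.26 log units; beyond the scatter). Compound 3 `COc1cc(-c2nnc3n2NC(c2ccco2)C(C(=O)c2ccc(C(F)(F)F)cc2)S3)cc(OC)c1OC` gives in this assay only a limit, > 100000 nM, so compound 3 stands at the limit of > 100000 nM in this assay, at which 1 of the 3 values shown sits. Compound 4 `COc1cc(-c2nnc3n2NC(c2ccco2)C(C(=O)c2ccc([N+](=O)[O-])cc2)S3)cc(OC)c1OC` differs from compound 3 by nitro in place of trifluoromethyl on an aromatic carbon. Among the compounds with values here, no measured step exchanges one substituent of the carbonyl-bearing ring for another of this kind; the single step on that ring, an 18-fold higher number from compound 1 to compound 2 (1.26 log units; beyond the scatter), is large but concerns methyl against methoxy, not trifluoromethyl against nitro, and no measured pair shares the furan of compound 3 and compound 4. With nothing to anchor a direction, the number for compound 4 is expected to stay close to that of compound 3, giving an estimated step of a number no higher from compound 3 to compound 4 (the limit leaves the size open). Compound 4 is estimated at 100000 nM, with a range from 20000 nM to 400000 nM, and a limit rather than a number is expected to be quite likely.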

Compound 4, half-maximal inhibitory concentration: 87800 nM
Compound 4: the middle estimate sits 1.1-fold (0.06 log units) above what was measured, within the range that was stated.
By their numbers in this assay, from the lowest: compound 1; then compounds 2 and 4 (each within the scatter of the next). At a limit, above all of these: compound 3.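

Exchanging trifluoromethyl for nitro on the carbonyl-bearing ring gives, in this assay, an at least 1.1-fold lower number from compound 3 to compound 4 (0.05 log units; that floor lies within the scatter). Within the data shown here, this is the first step at this position that keeps the furan in place, and compound 4 gives a number there, 87800 nM, so this position on the furan series can be read as a value. The real size of the step remains unknown because compound 3 stands at a limit of the assay: the limit of > 100000 nM in this assay, at which 1 of the 4 values shown sits.

Open, on these data alone, is whether the step seen between methyl and methoxy on this ring, with the other ring of compound 1 and compound 2, would carry over to the furan of compound 3 and compound 4. Also open, as far as these compounds go, is how an amine or a carboxylic acid at this same place on the ring would read in this assay.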